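Swapping the tail group on a rat microsome half-life series

The source may report more compounds than this note shows. Statements on the series, on what has been measured and on what is new or still open speak of the compounds shown alone.

Measured compounds:
- compound 1, `CCOc1cc(NC(=O)C2(NC(=O)c3ccc4c(C5CCCC5)c(-c5ncc(Cl)cn5)n(C)c4c3)CCC2)ccc1/C=C/C(=O)OCOP(=O)(O)OC(C)(C)C`, 0.133 h
- compound 2, `CCOc1cc(NC(=O)C2(NC(=O)c3ccc4c(C5CCCC5)c(-c5ncc(Cl)cn5)n(C)c4c3)CCC2)ccc1/C=C/C(=O)OCOP(=O)(O)O`, 0.15 h
- compound 3, `CCOc1cc(NC(=O)C2(NC(=O)c3ccc4c(C5CCCC5)c(-c5ncc(Cl)cn5)n(C)c4c3)CCC2)ccc1/C=C/C(=O)OCCOc1ccccc1`, 16.5 h

All three share one core and differ only in the group attached on a saturated chain carbon bound to an oxygen next to a carbonyl group. In an ADME assay (liver) for pharmacokinetics, with Liver microsome (Rattus norvegicus) as the target, using microsomes (on this read-out higher numbers stand for a longer-lived compound and lower numbers for a shorter-lived compound), compound 3 stands highest of the three, and its distance to both others lies beyond the scatter. The step of a 1.1-fold higher number from compound 1 to compound 2 (0.05 log units; within the scatter) was within the scatter, whereas a 120-fold higher number from compound 1 to compound 3 (2.09 log units; beyond the scatter) and a 110-fold higher number from compound 2 to compound 3 (2.04 log units; beyond the scatter) were both large.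

Compound 4, `CCOc1cc(NC(=O)C2(NC(=O)c3ccc4c(C5CCCC5)c(-c5ncc(Cl)cn5)n(C)c4c3)CCC2)ccc1/C=C/C(=O)OCC(=O)OC`, has not yet been measured in this assay. It differs from compound 3 by methoxycarbonyl in place of phenoxymethyl on a saturated chain carbon bound to an oxygen next to a carbonyl group. Both large steps recorded so far came from changing the group at exactly this place, so a change there is expected to move the number well beyond the scatter. Nothing measured tells whether methoxycarbonyl behaves more like the groups in compound 1 and compound 2 or like the phenoxymethyl of compound 3, so the estimate sits between them with a wide range. For compound 4 the expected step is a 17-fold lower number from compound 3 to compound 4 (1.22 log units; beyond the scatter), giving an estimated 1 h, with a range from 0.15 h to 8 h.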

Compound 4, half-life: 2.08 h
Beside the measured number, compound 4's estimate is 2.1-fold (0.32 log units) below it; low and high end bracket the measured number.
By their numbers in this assay, from the lowest: compounds 1 and 2 (each within the scatter of the next); then compound 4; then compound 3.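

Compound 4 shows that a group with no ring and no phosphorus, on a saturated chain carbon bound to an oxygen next to a carbonyl group, can give an intermediate half-life in this assay: it stands well above the two phosphorus-bearing compounds (a 14-fold higher number from compound 2 to compound 4 (1.14 log units; beyond the scatter); a 16-fold higher number from compound 1 to compound 4 (1.19 log units; beyond the scatter)) but under the phenoxymethyl compound (a 7.9-fold lower number from compound 3 to compound 4 (0.90 log units; beyond the scatter)). Going by these compounds alone, this position therefore gives three separate levels rather than only the low pair and the single high value seen before, and the six-membered aromatic ring of compound 3 is not needed to rise above compound 1 and compound 2, although compound 3 remains the highest of the four. Nothing available explains why these groups differ in this way.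

The compounds shown leave open whether the ester within methoxycarbonyl matters, which a carboxylic acid or an amide in its place could test. They also leave open how a longer chain, or an amine, at the same place would compare with methoxycarbonyl and phenoxymethyl.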